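The source may report more compounds than this note shows. Statements on the series, on what has been measured and on what is new or still open speak of the compounds shown alone.

Measured compounds:
compound 1 `Nc1scc(CN2CCN(c3cccc(C(F)(F)F)c3)CC2)c1C(=O)c1ccc(Cl)cc1`: 0%
compound 2 `Nc1scc(CN2CCN(c3ccc(F)cc3F)CC2)c1C(=O)c1ccc(Cl)cc1`: 0%
compound 3 `Nc1scc(CN2CCN(c3cccc(F)c3F)CC2)c1C(=O)c1ccc(Cl)cc1`: 0%

All three were tested in an assay on CHO cells for displacement of a labelled ligand from adenosine receptor A3 (Homo sapiens), read by scintillation counting, with a stated time of 120 min, tested at 10 uM; on this read-out higher numbers stand for more inhibition at the one concentration tested (going by the name of the read-out) and lower numbers for less inhibition. In this assay compound 1 gives 0%, compound 2 gives 0% and compound 3 gives 0%. Compound 3 therefore stands level with the other two: the step of no change at the digits printed from compound 1 to compound 3 (within the scatter), the step of no change at the digits printed from compound 2 to compound 3 (within the scatter) and the step of no change at the digits printed from compound 1 to compound 2 (within the scatter) all lie within the scatter, so nothing in this small set separates one compound from another.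

Compound 4 `Nc1scc(CN2CCN(c3c(Cl)cccc3Cl)CC2)c1C(=O)c1ccc(Cl)cc1` has not yet been measured. It differs from compound 3 in one place: 2,6-dichlorophenyl in place of 2,3-difluorophenyl on an amine nitrogen in a ring. The three measured steps each exchanged one substituted phenyl for another on the same amine nitrogen in a ring, and none of them moved the read-out beyond the scatter. The change to compound 4 is of the same kind, so no step beyond the scatter is expected in this assay. The expected step is no change at the digits printed from compound 3 to compound 4 (within the scatter). For compound 4 the estimate is 0%, with a range from -10% to 12%.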

Compound 4, a percentage reported as inhibition, at one concentration (the size of the read-out at that concentration, not a potency): 1%
Beside the measured number, compound 4's estimate is 1 percentage points below it; the measured number falls inside the stated range.
By their numbers in this assay, from the lowest: compounds 1, 2, 3 and 4 (each within the scatter of the next).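

In this assay the 2,6-dichlorophenyl group on the amine nitrogen in a ring gives a number 1 percentage points higher from compound 3 to compound 4 (within the scatter) and a number 1 percentage points higher from compound 2 to compound 4 (within the scatter) and a number 1 percentage points higher from compound 1 to compound 4 (within the scatter) in this set. For the compounds shown here, the earlier compounds carried fluorine only on this aryl group, so compound 4 adds the first evidence that a chlorine-bearing group here also stays within the scatter, even though it has the same heavy-atom count as the 2,3-difluorophenyl group it replaces. No measurement available here explains why the read-out stays flat across these groups.

As far as these compounds go, all four compounds carry a halogen-bearing phenyl at this position, so it remains open whether a phenyl bearing an amine or a carboxylic acid would give a read-out beyond the scatter. The same question stands for a longer chain on this nitrogen.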